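A second fluoro on the aromatic ring

The source may report more compounds than this note shows. Statements on the series, on what has been measured and on what is new or still open speak of the compounds shown alone.

In a functional assay on RAW264.7 cells (Mus musculus) for inhibition (a higher number here means a weaker inhibitor, a lower number a stronger inhibitor), compound 1 `CCOC(=O)C1=CCCCC1S(=O)(=O)Nc1ccccc1F`, with a 2-fluorophenyl group on the sulfonamide nitrogen, gives 75 nM. Compound 2 `CCOC(=O)C1=CCCCC1S(=O)(=O)Nc1ccc(F)cc1`, with a 4-fluorophenyl group there instead, gives 110 nM, so the two stand level within the usual scatter. Compound 3 `CCOC(=O)C1=CCCCC1S(=O)(=O)Nc1ccc(F)cc1F` puts fluoro in place of hydrogen on an aromatic carbon of compound 2, ortho to a large group and meta to the fluoro group already present: fluoro in place of hydrogen on an aromatic carbon. Among the measured compounds shown here, the only measured step bearing on this, a 1.5-fold higher number from compound 1 to compound 2 (0.17 log units; within the scatter), moved a fluoro rather than adding one, so it gives no direct size for the addition. Compound 3 holds fluoro at both places, and in this assay a modest move to a lower number is expected, perhaps none beyond the scatter. The estimated step is a 2.2-fold lower number from compound 2 to compound 3 (0.34 log units; beyond the scatter). Compound 3 is expected at 50 nM, within a range of 15 nM to 130 nM.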

Compound 3, half-maximal inhibitory concentration: 16 nM
Compound 3: middle estimate off by 3.1-fold (0.49 log units), on the high side, within the range that was stated.
By their numbers in this assay, from the lowest: compound 3; then compounds 1 and 2 (each within the scatter of the next).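

Both a 6.9-fold lower number from compound 2 to compound 3 (0.84 log units; beyond the scatter) and a 4.7-fold lower number from compound 1 to compound 3 (0.67 log units; beyond the scatter) come from fluoro in place of hydrogen on an aromatic carbon, and both lie beyond the scatter. The earlier pair stood level with a single fluoro at either place, whereas holding fluoro at both places gives a clearly lower number than either single-fluoro compound, so here the two fluoro groups together do what neither does alone. Nothing measured here accounts for the size of this drop.

The compounds shown carry only fluoro at these places, so it remains open whether a chloro, a methyl or a methoxy group would also lower the number. Also open, from the compounds shown here alone, is whether the drop would persist with a carboxylic acid in place of the ethyl ester.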